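Series notes: diethylamino in place of 4-methylpiperazin-1-yl

A few compounds are considered here, and "the series" means these few. Any claim that something is new, unique, unknown or untested is made for them only; others in the source may bear on it.

Of the compounds shown here, three have numbers so far in an ADME assay on L6 cells (Rattus norvegicus) for cytotoxicity, read by resazurin assay, with a stated time of 72 h (a lower number here means a stronger inhibitor, a higher number a weaker inhibitor), and all of them sit in a narrow part of the scale. Compound 1 (`CN(C)C12CC(OC(=O)CN3CCCC3)C(C(c3ccccc3)C1)C(c1ccccc1)C2`) gives 32700 nM in this read-out. Compound 2 (`CN1CCN(CC(=O)OC2CC3(N(C)C)CC(c4ccccc4)C2C(c2ccccc2)C3)CC1`) gives 39900 nM there. Compound 3 (`CN1CCN(CCC(=O)N2CCC3(N(C)C)CC(c4ccccc4)C2C(c2ccccc2)C3)CC1`) gives 128000 nM as the highest number of the set. Compound 2 therefore sits level with compound 1 within the scatter, while the gap up to compound 3 lies beyond it.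

Among the compounds with values here, the next step leads to compound 4 (`CCN(CC)CC(=O)OC1CC2(N(C)C)CC(c3ccccc3)C1C(c1ccccc1)C2`), which has no measurement yet. The change is diethylamino in place of 4-methylpiperazin-1-yl on a saturated chain carbon bound to a carbonyl carbon on a saturated chain carbon bound to a carbonyl carbon.

Within the data shown here, only one measured step touches this place: a 1.2-fold higher number from compound 1 to compound 2 (0.09 log units; within the scatter) stays within the scatter, with 4-methylpiperazin-1-yl in place of pyrrolidin-1-yl. Among the measured compounds shown here, that is thin support, and no measured compound carries diethylamino. Nothing beyond the scatter is therefore expected in this assay for this exchange. The expected change is a 1.2-fold lower number from compound 2 to compound 4 (0.08 log units; within the scatter) and it is read as no real shift. Compound 4 is estimated at 33000 nM with an expected range from 15000 nM to 75000 nM in this read-out.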

Compound 4, half-maximal inhibitory concentration: 30100 nM
Beside the measured number, compound 4's estimate is 1.1-fold (0.04 log units) above it; measured number inside the range.
By their numbers in this assay, from the lowest: compounds 4, 1 and 2 (each within the scatter of the next); then compound 3.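

In this assay diethylamino in place of 4-methylpiperazin-1-yl gives a 1.3-fold lower number from compound 2 to compound 4 (0.12 log units; within the scatter) and diethylamino in place of pyrrolidin-1-yl gives a 1.1-fold lower number from compound 1 to compound 4 (0.04 log units; within the scatter) so neither exchange leaves the scatter. Within the data shown here, the earlier compounds showed only two ring amines on a saturated chain carbon bound to a carbonyl carbon; compound 4 adds an open-chain amine at this place, and across compounds 1, 2 and 4 neither removing the ring nor going from the two nitrogens of 4-methylpiperazin-1-yl to the single nitrogen of diethylamino produces a step beyond the scatter. Nothing shown here offers an explanation for this flat result.

On these data alone, compounds 1, 2 and 4 all carry a tertiary amine at this place, so it remains open whether a carboxylic acid, a primary amine or morpholin-4-yl would produce a step beyond the scatter. As far as these compounds go, it is equally open whether a longer chain carrying diethylamino would stay level with compound 4 in this assay or move away from it.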